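Methyl added to a chain carbon in an aryl urea series

A few compounds are considered here, and "the series" means these few. Any claim that something is new, unique, unknown or untested is made for them only; others in the source may bear on it.

Compound 1 `Cc1cccc(NC(=O)N[C@@H](C)c2ccccc2)c1` gives 100% in an ADME assay on the whole organism with Oryza sativa as the target, tested at 10 uM; on this read-out lower numbers stand for a stronger effect and higher numbers for a weaker effect at the one concentration tested. Compound 2 `CCc1cccc(NC(=O)N[C@@H](C)c2ccccc2)c1` gives 86% in this assay, and the step of a number 14 percentage points lower from compound 1 to compound 2 (beyond the scatter) follows the change (methyl in place of hydrogen on a saturated chain carbon bound to an aromatic carbon). Compound 3 `CC(C)c1ccccc1NC(=O)N[C@H](C)c1ccccc1` gives 17% in this assay, the lowest of the three numbers; the difference between its core and the core of compound 1 is not broken down here. Compound 4 `C[C@@H](NC(=O)Nc1ccccc1C(C)(C)C)c1ccccc1` has not yet been measured. It differs from compound 3 by methyl in place of hydrogen on a saturated chain carbon bound to an aromatic carbon and two saturated chain carbons, the same kind of change as from compound 1 to compound 2, but here the saturated chain carbon is bound to an aromatic carbon and two saturated chain carbons, whereas in compound 2 it is bound only to an aromatic carbon. For compound 4 a step of a number 7 percentage points lower from compound 3 to compound 4 (within the scatter) is expected, because the earlier step of a number 14 percentage points lower from compound 1 to compound 2 (beyond the scatter) was modest and pointed to lower numbers, and compound 3 already sits low. The estimate for compound 4 in this assay is therefore 10%, within 2% to 30%.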

Compound 4, a percentage reported as activity, at one concentration (the size of the read-out at that concentration, not a potency): 17%
Estimate against measurement, compound 4: 7 percentage points below; low and high end bracket the measured number.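

In this assay, replacing isopropyl with tert-butyl, which puts methyl in place of hydrogen on a saturated chain carbon bound to an aromatic carbon and two saturated chain carbons, gives no change at the digits printed from compound 3 to compound 4 (within the scatter). Set beside the earlier step, this result gives no ground for saying that the change behaves differently on the two cores, even though one step lies beyond the scatter and the other within it: the same change on two cores in this assay, a number 14 percentage points lower (beyond the scatter) from compound 1 to compound 2 and no change at the digits printed (within the scatter) from compound 3 to compound 4, 14 percentage points apart, within the scatter of two such steps With only two pairs, however, this does not show that the change has a fixed size in this series, nor does it say how the change would behave on any other core.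

The compounds shown leave open how the read-out would respond if a group of another kind, such as a methoxy group, a chlorine atom or a carboxylic acid, took the place of the tert-butyl group. They also leave open whether a longer chain would follow the two steps seen here.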